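The compounds below may be only part of what the source reports. "The series", "measured", "known", "first", "only" and "open" are said of these compounds alone.

Compound 3 `COc1ccccc1-c1csc(N/N=C/c2cc(OC)c(OC)c(Br)c2Br)n1` stands at a boundary of the data. In a functional assay on HepG2 cells (Homo sapiens) for inhibition, read by MTT assay, with a stated time of 48 h (on this read-out higher numbers stand for weaker inhibition and lower numbers for stronger inhibition), compound 3 gives > 100000 nM, which is a limit of the assay and not a number. Compound 1 `COc1cc(/C=N/Nc2nc(-c3ccc(C(F)(F)F)cc3)cs2)c(Br)c(Br)c1OC` likewise gives > 100000 nM in this assay, again a limit. Compound 2 `COc1cc(/C=N/Nc2nc(-c3cccc(Br)c3)cs2)cc(Br)c1OC` gives 66200 nM in this assay. The change from compound 3 to compound 4 `COc1cc(/C=N/Nc2nc(-c3cccc(Br)c3)cs2)c(Br)c(Br)c1OC` is 3-bromophenyl in place of 2-methoxyphenyl on an aromatic carbon. Among the measured compounds shown here, the only measured step at a comparable place, a step that the two limits leave unreadable from compound 1 to compound 3, cannot be read owing to the limit of > 100000 nM in this assay, at which 2 of the 3 values shown sit, so no measured step shows how large a swap on that aromatic carbon can be; compound 2, the one compound bearing 3-bromophenyl, shows a number just under the limit. Compound 4 is therefore expected near the limit, at 100000 nM with a range of 40000 nM to 250000 nM, meaning an expected step of a number no higher from compound 3 to compound 4 (the limit leaves the size open) that may itself end only as a limit.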

Compound 4, half-maximal inhibitory concentration: > 100000 nM
Compound 4: a limit, no number; the forecaster's own chance of this, stated with the estimate: 60%; the middle value sits exactly at the limit.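

In this assay compound 4 gives > 100000 nM, which is a limit of the assay and not a number. Among the compounds shown here, the one readable step, bromo in place of hydrogen on an aromatic carbon with 3-bromophenyl kept, is an at least 1.5-fold higher number from compound 2 to compound 4 (0.17 log units; that floor lies within the scatter), so it shows no change beyond the scatter. The steps among compound 1, compound 3 and compound 4 cannot be read, because these values sit at one limit: the limit of > 100000 nM in this assay, at which 3 of the 4 values shown sit.

As far as these compounds go, it remains open whether any group at this place on the core of compound 4 gives a number under that limit. An amine or a carboxylic acid in place of 3-bromophenyl would be one such test.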